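The source may hold more compounds than are shown below. What is called first, only, known or untested is meant among the compounds shown, and "the series" means these compounds.

Measured so far:
compound 1 `CCS[C@]1(C(=O)O)C=C[C@@H](NC(C)=O)[C@H]([C@H](O)[C@H](O)CO)O1`: > 1000000 nM
compound 2 `CC(=O)N[C@@H]1C=C[C@@](OC(C)C)(C(=O)O)O[C@H]1[C@H](O)[C@H](O)CO`: > 1000000 nM

In an assay on HEK293 cells for inhibition of sialidase-3 (Homo sapiens), read by fluorescence, with a stated time of 1 h (on this read-out higher numbers stand for weaker inhibition and lower numbers for stronger inhibition), compound 1 gives only a limit, > 1000000 nM. Compound 2 likewise gives only a limit in this assay, > 1000000 nM. Both values sit at the limit of > 1000000 nM in this assay, at which 2 of the 2 values shown sit, so neither compound shows measurable inhibition. Compound 3 `CC(=O)N[C@@H]1C=C[C@](OC(C)C)(C(=O)O)O[C@H]1[C@H](O)[C@H](O)CO` has not yet been measured. It is related to compound 2 by configuration alone: the two compounds have the same atoms and bonds and differ only in configuration as drawn: 1 of 5 stereo elements differ; a stereocentre at a saturated ring carbon is drawn S in compound 2 and R in compound 3. Within the data shown here, no two measured compounds differ in a single place, so no measured step can guide the size of this change. Compound 3 is expected to stay at or near the limit, which means a step of a number no higher from compound 2 to compound 3 (the limit leaves the size open). For compound 3 the estimate is 1000000 nM, with a range from 100000 nM to 10000000 nM.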

Compound 3, half-maximal inhibitory concentration: > 1000000 nM
Compound 3: a limit, no number (the forecaster's own chance of this, stated with the estimate: 80%); the middle value lies on the limit itself.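

Compound 1, compound 2 and compound 3 all stand at one limit in this assay, so no step between them can be read: the limit of > 1000000 nM in this assay, at which 3 of the 3 values shown sit.

The compounds shown leave open whether the configuration at that saturated ring carbon, or isopropoxy in place of ethylsulfanyl, changes inhibition at all.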